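A Nitro Group Replaces Fluorine on a Silent Core

This account rests on a few compounds, and the source may have more. Where it says the series, first, only, none or still open, it means among the compounds named here.

Of the compounds shown here, three built on one shared core have been tested in a functional assay on L1210 cells (Mus musculus) for cytotoxicity, with a stated time of 48 h; on this read-out lower numbers stand for stronger inhibition and higher numbers for weaker inhibition. Compound 1 `Fc1ccc(-c2cn3nc(Cc4ccc(Cl)cc4)sc3n2)cc1` gives > 250000 nM, which is a limit of the assay and not a number. Compound 2 `Clc1ccc(-c2cn3nc(Cl)sc3n2)cc1` likewise gives only a limit, > 250000 nM. Compound 3 `Fc1ccc(-c2nc3sc(Cc4ccc(Cl)cc4)nn3c2Br)cc1` also reaches no more than a limit, > 250000 nM. Compound 3 therefore stands at the edge of what this assay can report, alongside every other measured compound, because of the limit of > 250000 nM in this assay, at which 3 of the 3 values shown sit.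

Among the measured compounds shown here, the single measured step that changes one place, a step that the two limits leave unreadable from compound 1 to compound 3, cannot be read in size, since both of its ends are limits.

Compound 4 `O=[N+]([O-])c1ccc(-c2nc3sc(Cc4ccc(Cl)cc4)nn3c2Br)cc1` differs from compound 3 in one place: nitro in place of fluoro on an aromatic carbon. For the measured compounds named here, no measured step involves this exchange, and the one step that is known gives no readable size, so nothing in the data points up or down. With every measured value resting at the limit, compound 4 is expected to rest there as well. The estimate for compound 4 in this assay is 250000 nM, with a range from 100000 nM to 1000000 nM. The expected step is accordingly a number no higher from compound 3 to compound 4 (the limit leaves the size open), which is to say no movement that the assay could register.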

Compound 4, half-maximal inhibitory concentration: 94000 nM
Estimate against measurement, compound 4: 2.7-fold (0.42 log units) above; the whole stated range lies above it.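

In this assay, nitro in place of fluoro on an aromatic carbon, para to a large group, gives an at least 2.6-fold lower number from compound 3 to compound 4 (0.42 log units; beyond the scatter), so a change at this place on the six-membered aromatic ring can move the read-out on a core that had otherwise shown nothing readable. The result for compound 3 is a limit and not a number, which means the step has a known minimum but no known full size. Compound 4 is the only compound shown that comes off the limit, and this gives the series its first real number for later comparisons, where the earlier compounds offered none: the limit of > 250000 nM in this assay, at which 3 of the 4 values shown sit.

Going by these compounds, one exchange cannot separate what matters here, since the entering nitro differs from fluoro both in its heavy atoms and in carrying hydrogen-bond acceptors, and it remains open whether another group at this place, such as an amine, a nitrile or a carboxylic acid, would also lift the compound off the limit. On these data alone, it is equally open whether nitro would have the same effect on compound 1, which carries hydrogen where compound 3 carries bromo.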